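This account rests on a few compounds, and the source may have more. Where it says the series, first, only, none or still open, it means among the compounds named here.

Within the data shown here, compound 2 `C=C1C[C@]23C[C@@]1(O)CC[C@H]2c1cc(Br)c(O)c(C)c1[C@@H]3Cn1cc(-c2ccc(F)cc2)nn1` is the only compound here whose potency comes out as a number rather than a limit. In a functional assay on HL-60 cells (Homo sapiens) for cytotoxicity, read by MTT assay, with a stated time of 4 days (on this read-out lower numbers stand for stronger inhibition and higher numbers for weaker inhibition), compound 2 gives 6600 nM. Compound 1 `Cc1c(O)ccc2c1[C@H](Cn1cc(-c3ccc(F)cc3)nn1)[C@@]13CC(=O)[C@@](C)(CC[C@@H]21)C3` reaches only the limit of > 20000 nM in this assay. Compound 3 `C=C1C[C@]23C[C@@]1(O)CC[C@H]2c1ccc(O)c(C)c1[C@@H]3Cn1cc(-c2ccc(F)cc2)nn1` likewise reaches only the limit of > 20000 nM in this assay. Among the measured compounds shown here, the one measured step, an at least 3.0-fold higher number from compound 2 to compound 3 (0.48 log units; beyond the scatter), concerns the bromo group on the shared core, and it ends at a limit, as the limit of > 20000 nM in this assay, at which 2 of the 3 values shown sit, records. Compound 4 `C=C1C[C@]23C[C@@]1(O)CC[C@H]2c1cc(Br)c(O)c(C)c1[C@@H]3Cn1cc(-c2ccc(Cl)cc2)nn1` differs from compound 2 in a different place: chloro in place of fluoro on an aromatic carbon. For the measured compounds named here, no measured step touches that position, so nothing in the data points to a move in either direction, and the expectation is a change that stays within the scatter, expressed as a 1.1-fold lower number from compound 2 to compound 4 (0.04 log units; within the scatter). On that basis compound 4 is estimated at 6000 nM in this assay, with a plausible range from 2500 nM to 15000 nM.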

Compound 4, half-maximal inhibitory concentration: 5590 nM
Beside the measured number, compound 4's estimate is 1.1-fold (0.03 log units) above it, within the range that was stated.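

In this assay, the swap from 4-fluorophenyl to 4-chlorophenyl gives a 1.2-fold lower number from compound 2 to compound 4 (0.07 log units; within the scatter), so on this read-out the fluoro and chloro compounds cannot be told apart at this position on the aromatic ring. Among these compounds, this is the first measured step at this position, and because it has a number at both ends, its size can be read directly. The bromo step is different, since compound 3 gives only a limit rather than a number: the limit of > 20000 nM in this assay, at which 2 of the 4 values shown sit.

The pair shows only that one halogen can stand in for the other here while the bromo group is present, so the same swap on the core of compound 3 remains an open question. On these data alone, it also remains open whether an amine, a carboxylic acid or a longer chain such as propyl at this position would shift the number beyond the scatter.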